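The source may hold more compounds than are shown below. What is called first, only, known or untested is meant among the compounds shown, and "the series" means these compounds.

Three compounds sharing one core were tested in an assay on isolated protein for agonist activity at Bile acid receptor (Homo sapiens), read by AlphaScreen, with a stated time of 30 min; a higher number here means a larger maximal response, a lower number a smaller maximal response. Compound 1 `Cc1nn(-c2ccccc2I)c2c1C(c1ccc(Oc3ccccc3)cc1)SC(C)C(=O)N2` gives 130%, the highest of the three numbers. Compound 3 `Cc1ccccc1-n1nc(C)c2c1NC(=O)[C@H](C)S[C@@H]2c1ccc(-c2ccsc2)cc1` gives 68%, a number beyond the scatter below compound 1, and compound 2 `COc1ccccc1-n1nc(C)c2c1NC(=O)[C@H](C)S[C@@H]2c1ccc(Oc2ccccc2)cc1` gives 37%, further below still. The step to compound 4 `Cc1nn(-c2ccccc2F)c2c1C(c1ccc(Oc3ccccc3)cc1)SC(C)C(=O)N2` is a single change: fluoro in place of iodo on an aromatic carbon. Among the compounds with values here, no measured pair shows this exact exchange, so the size of the step is open, and compounds 2 and 3 differ from compound 1 in more than one place, giving no direct guide. A moderate fall is expected, as the estimated step of a number 35 percentage points lower from compound 1 to compound 4 (beyond the scatter). Compound 4 is expected to reach 95%, between 55% and 135%.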

Compound 4, largest response reached (reported as efficacy), in percent of the reference or control that the assay uses: 72%
Compound 4: the middle estimate sits 23 percentage points above what was measured; the range from low to high includes it.
By their numbers in this assay, from the lowest: compound 2; then compounds 3 and 4 (each within the scatter of the next); then compound 1.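

With the rest of the molecule unchanged, the maximal response shows a number 58 percentage points lower from compound 1 to compound 4 (beyond the scatter) when fluoro takes the place of iodo on this aromatic carbon, ortho to a large group. This shows that exchanging one atom at this place can move the response beyond the scatter, which compounds 2 and 3 could not show, as each differs from compound 1 in more than one place. Nothing given here explains the fall. Chloro and bromo at this place remain open, so it is unclear whether the response changes gradually from fluoro to iodo. On these data alone, how plain hydrogen here would compare is also open.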